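A few compounds are considered here, and "the series" means these few. Any claim that something is new, unique, unknown or untested is made for them only; others in the source may bear on it.

Compound 1 `O=C(O)CCc1ccc(C#Cc2ccnc(-c3ccccc3)c2)cc1` stands toward the higher end of three numbers in an in vitro functional assay on 1321-N1 cells for agonist activity at Free fatty acid receptor 1 (Homo sapiens), read by fluorescence, spectrophotometry and calcium flux; a lower number here means that less compound is needed, a higher number that more compound is needed for the effect: compound 1 gives 186 nM, compound 2 `O=C(O)CCc1ccc(C#Cc2cccs2)cc1` gives 251 nM, and compound 3 `Cc1c(C#Cc2ccc(CCC(=O)O)cc2)cc(Cl)nc1Cl` gives 43.7 nM. The values of compound 1 and compound 2 lie within the usual scatter of each other, whereas compound 3 needs a clearly smaller amount than compound 1. Compound 4 `COc1cc(C#Cc2ccc(CCC(=O)O)cc2)ccn1` differs from compound 1 in one place: methoxy in place of phenyl on an aromatic carbon. For the measured compounds named here, no measured pair shows this change directly, so the expectation leans on compound 3, whose value of 43.7 nM comes from a similarly decorated ring. The step from compound 1 to compound 4 is estimated as a modest move toward a lower number, a 1.3-fold lower number from compound 1 to compound 4 (0.12 log units; within the scatter), one that the scatter could still hide. Compound 4 is therefore expected to give about 140 nM, with a range from 50 nM to 400 nM.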

Compound 4, half-maximal effective concentration: 525 nM
Compound 4: middle estimate off by 3.8-fold (0.57 log units), on the low side; the whole stated range lies below it.
By their numbers in this assay, from the lowest: compound 3; then compounds 1 and 2 (each within the scatter of the next); then compound 4.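

At this position, next to the ring nitrogen, methoxy in place of phenyl gives a 2.8-fold higher number from compound 1 to compound 4 (0.45 log units; beyond the scatter) in this assay, so more compound is needed with the smaller group. For the compounds shown here, this is the first direct reading of a change at this place, and it shows that the two groups are not interchangeable here. No measurement shown explains the step.

A single pair cannot separate losing the phenyl ring from gaining the oxygen. Going by these compounds, how an ethoxy group or an amine would behave at this position remains open.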